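Chloro for Methyl: One Change Made on Two Cores

The source may hold more compounds than are shown below. What is called first, only, known or untested is meant among the compounds shown, and "the series" means these compounds.

Compound 1 `CC1=NNC(=O)C1C(c1c(-c2ccccc2)[nH]c2ccc(C)cc12)c1c(-c2ccccc2)[nH]c2ccc(C)cc12` and compound 3 `CC1=NNC(=O)C1C(c1c[nH]c2ccccc12)c1c(-c2ccccc2)[nH]c2ccc(C)cc12` differ in their cores; the difference between the two cores is not broken down here. In a functional assay on HeLa cells (Homo sapiens) for cytotoxicity, read by MTT assay (a higher number here means a weaker inhibitor, a lower number a stronger inhibitor), compound 1 gives 32700 nM. In this assay compound 3 gives 2400 nM, the lowest of the two numbers and well apart from compound 1. Compound 2 `CC1=NNC(=O)C1C(c1c(-c2ccccc2)[nH]c2ccc(C)cc12)c1c(-c2ccccc2)[nH]c2ccc(Cl)cc12` arises from compound 1 by chloro in place of methyl on an aromatic carbon. In this assay compound 2 gives > 100000 nM, which is a limit of the assay rather than a number. That move is an at least 3.0-fold higher number from compound 1 to compound 2 (0.48 log units; beyond the scatter), a size that rests on (the limit of > 100000 nM in this assay, at which 1 of the 3 values shown sits). Compound 4 `CC1=NNC(=O)C1C(c1c[nH]c2ccccc12)c1c(-c2ccccc2)[nH]c2ccc(Cl)cc12` stands to compound 3 as compound 2 stands to compound 1, by chloro in place of methyl on an aromatic carbon; the two places are described in the same words, so this is the same change. What guides the expectation for compound 4 is the measured step of an at least 3.0-fold higher number from compound 1 to compound 2 (0.48 log units; beyond the scatter), seen only once among these compounds. For compound 4 the step in this assay is expected to be a 3.8-fold higher number from compound 3 to compound 4 (0.57 log units; beyond the scatter). Compound 4 is therefore estimated at 9000 nM, expected to fall between 3000 nM and 40000 nM.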

Compound 4, half-maximal inhibitory concentration: 3800 nM
Beside the measured number, compound 4's estimate is 2.4-fold (0.37 log units) above it; the range from low to high includes it.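

Carried to a second core, chloro in place of methyl on an aromatic carbon gives a 1.6-fold higher number from compound 3 to compound 4 (0.20 log units; within the scatter) in this assay, so on this core the swap moves the number by no more than repeated measurements would. The two cores together do not show whether the change carries over with the same size or depends on the core: the same change on two cores in this assay, an at least 3.0-fold higher number (0.48 log units; beyond the scatter) from compound 1 to compound 2 and a 1.6-fold higher number (0.20 log units; within the scatter) from compound 3 to compound 4; the limit leaves it open whether they differ Compound 2 gives > 100000 nM, which is a limit of the assay and not a number.

The compounds shown leave open how another group on this aromatic carbon, such as fluoro, methoxy, an amine or a carboxylic acid, would read in this assay on either core. They also leave open whether chloro in place of methyl would give a step like either of these two on a third core, or at another aromatic carbon of the same six-membered ring.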